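The source may hold more compounds than are shown below. What is called first, only, known or untested is meant among the compounds shown, and "the series" means these compounds.

Among the compounds with values here, compound 1 `CN1CCC(NC(=O)c2ccc(Nc3ncc([N+](=O)[O-])c(NC4CCCC4)n3)cc2)CC1` is one of three compounds so far measured in a functional assay on A549 cells (Homo sapiens) for cytotoxicity, read by MTT assay, with a stated time of 48 h; a higher number here means a weaker inhibitor, a lower number a stronger inhibitor. In this assay compound 1 gives 42300 nM, the highest number of the three. Compound 2 `CN1CCN(c2ccc(Nc3ncc(F)c(NC4CCCC4)n3)cc2)CC1` gives 37200 nM, a number within the scatter of that of compound 1. Compound 3 `COc1cc(C(=O)NC2CCN(C)CC2)ccc1Nc1ncc(Br)c(NC2CCCC2)n1` gives 2500 nM, a number far lower than that of compound 1 and well beyond the scatter.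

Compound 4 `CN1CCC(NC(=O)c2ccc(Nc3ncc(Cl)c(NC4CCCC4)n3)cc2)CC1` has not yet been measured. It differs from compound 1 in a single place: chloro in place of nitro on an aromatic carbon, in words, chloro in place of nitro on an aromatic carbon. Within the data shown here, no measured pair shows exactly this exchange, so the size of the step can only be judged loosely. Compound 2 carries fluoro and compound 3 carries bromo on the shared core, but each also differs from compound 1 elsewhere, so neither isolates the halogen on its own. A lower number than that of compound 1 seems somewhat more likely than a higher one, though a step within the scatter cannot be excluded. Compound 4 is therefore expected to give 10000 nM in this assay, with a range from 2500 nM to 40000 nM. That estimate amounts to an expected step of a 4.2-fold lower number from compound 1 to compound 4 (0.63 log units; beyond the scatter).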

Compound 4, half-maximal inhibitory concentration: 1800 nM
For compound 4 the middle estimate is 5.6-fold (0.74 log units) above the measured one; measured number below the stated range.
By their numbers in this assay, from the lowest: compounds 4 and 3 (each within the scatter of the next); then compounds 2 and 1 (each within the scatter of the next).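

In this assay, chloro in place of nitro on an aromatic carbon gives a 24-fold lower number from compound 1 to compound 4 (1.37 log units; beyond the scatter), a large step. This is the first pair among the compounds shown that differs only at this position, which is ortho to a cyclopentylamino group and two atoms from the ring nitrogen, and it shows that this one exchange can change the number substantially while the rest of compound 1 stays the same. The exchange replaces nitro, with its 3 heavy atoms and 2 hydrogen-bond acceptors, with a single chlorine atom that has no hydrogen-bond acceptors, but no measurement here links the step to either of these differences or explains it in any other way.

On these data alone, compound 2 and compound 3 also carry a halogen at this position but differ from compound 4 elsewhere, so the effect of fluoro or bromo with the rest of compound 4 in place remains open. Also open, as far as these compounds go, is how a methyl group, a nitrile or an amine at this position would compare with chloro and nitro on the same core.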